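The source may report more compounds than this note shows. Statements on the series, on what has been measured and on what is new or still open speak of the compounds shown alone.

Measured so far:
- compound 1, `CC(=O)N1N=C(c2ccc(Br)cc2)CC1c1cccc(Cl)c1Cl`, in a functional assay on PC-3 cells (Homo sapiens) for cytotoxicity, read by sulforhodamine B assay, with a stated time of 48 h (on this read-out lower numbers stand for stronger inhibition and higher numbers for weaker inhibition), gives 38800 nM
- compound 2, `CC(=O)N1N=C(c2ccco2)CC1c1ccccc1[N+](=O)[O-]`, in this assay gives 19000 nM
- compound 3, `CC(=O)N1N=C(c2cccc3ccccc23)CC1c1ccccc1`, in this assay gives 8460 nM

Compound 3 stands lowest of the three numbers; its nearest neighbour is compound 2, whose number lies beyond the scatter above it, and compound 1 lies further still. Compound 4, `COc1ccc(C2CC(c3cccc4ccccc34)=NN2C(C)=O)cc1`, differs from compound 3 by one change: methoxy in place of hydrogen on an aromatic carbon, para to a large group. Within the data shown here, no pair of measured compounds shows this change, so nothing here tells its effect. The step from compound 3 to compound 4 is therefore expected to be small, within the scatter, with no set direction: a 1.1-fold lower number from compound 3 to compound 4 (0.05 log units; within the scatter). Compound 4 is estimated at 7500 nM, between 2500 nM and 22000 nM.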

Compound 4, half-maximal inhibitory concentration: 4930 nM
Compound 4: the middle estimate sits 1.5-fold (0.18 log units) above what was measured; measured number inside the range.
By their numbers in this assay, from the lowest: compounds 4 and 3 (each within the scatter of the next); then compound 2; then compound 1.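

With methoxy in place of hydrogen on an aromatic carbon, para to a large group, this assay gives a 1.7-fold lower number from compound 3 to compound 4 (0.23 log units; within the scatter). Among these compounds, this is the first single-change pair here, and it shows that, on this core, the phenyl to 4-methoxyphenyl swap leaves the two compounds indistinguishable in this read-out. No other measurement bears on this result. On these data alone, what an amine, a carboxylic acid or a longer chain at this place would give stays open. So does whether methoxy behaves alike alongside a different group on the core.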